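The source may report more compounds than this note shows. Statements on the series, on what has been measured and on what is new or still open speak of the compounds shown alone.

Measured so far:
Compound 1 `COc1ncc(-c2ccc3ncnc(N[C@H]4CCCN(C(=O)CCl)C4)c3c2)cc1C#N`: 380 nM
Compound 2 `CCOC(=O)CN1CCC[C@H](Nc2ncnc3ccc(-c4cnc(OC)c(C(F)(F)F)c4)cc23)C1`: 230 nM

Both values come from a functional assay on SU-DHL-6 cells (Homo sapiens) for antiproliferative activity, read by MTT assay; a higher number here means a weaker inhibitor, a lower number a stronger inhibitor. They lie within the usual scatter of each other, so compound 1 stands level with compound 2, and the two cannot be ranked. Among the measured compounds shown here, no pair of measured compounds shows a change in one place, so there is no measured step to serve as a guide.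

The next compound, compound 3 `COc1ncc(-c2ccc3ncnc(N[C@H]4CCCN(C(=O)C5CCNCC5)C4)c3c2)cc1C#N`, keeps the core of compound 1 and carries piperidin-4-yl in place of chloromethyl on a carbonyl carbon. For the measured compounds named here, with no precedent for this swap, the expectation is a loose one, anchored on compound 1 at 380 nM. A modest loss of activity in this assay is expected, which would mean a somewhat higher number, although a result within the scatter would be no surprise. The expected change is a 1.8-fold higher number from compound 1 to compound 3 (0.27 log units; within the scatter). For compound 3 the estimated value is 700 nM, with an expected range of 170 nM to 3000 nM.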

Compound 3, half-maximal inhibitory concentration: 2440 nM
The estimate for compound 3 lay 3.5-fold (0.54 log units) below the measured number; the range from low to high includes it.
By their numbers in this assay, from the lowest: compounds 2 and 1 (each within the scatter of the next); then compound 3.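

In this assay, among the compounds shown here, piperidin-4-yl in place of chloromethyl on a carbonyl carbon gives the first measured step in this set of compounds, a 6.4-fold higher number from compound 1 to compound 3 (0.81 log units; beyond the scatter), and this step lies beyond the usual scatter. This shows that the position is not indifferent to the group it carries: with the rest of the molecule unchanged, going from a group of 2 heavy atoms with no ring to one of 6 heavy atoms with a six-membered non-aromatic ring weakens the effect on these cells. No independent measurement is available to explain this weakening.

The swap changes several things at once, removing the chlorine and adding a ring, a ring nitrogen and a hydrogen-bond donor, so a single step cannot show which of these changes matters. Cyclohexyl on the same carbonyl carbon would keep the ring without the nitrogen, while plain methyl would lose the chlorine without adding a ring, and either comparison could begin to separate these contributions.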